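Small Alkyl Groups on the Cyanoguanidine Nitrogen

The compounds below may be only part of what the source reports. "The series", "measured", "known", "first", "only" and "open" are said of these compounds alone.

Compound 3 `N#CNC(=N)NCCCCn1nc(-c2ccccc2)ccc1=O` carries an unsubstituted cyanoguanidine on its chain, and in a functional assay on the whole organism (stomach) with Rattus norvegicus as the target (a lower number here means that less compound is needed, a higher number that more compound is needed for the effect), compound 3 gives 77.2 mg/kg. Of the two plain numbers shown, compound 3 sits at the low end, but compound 2 `CC/N=C(/NC#N)NCCCCCn1nc(-c2ccccc2)ccc1=O` gives 100 mg/kg in this assay, and the gap between them lies within the scatter, so neither can be called the stronger of the two. Compound 1 `CCC/N=C(/NC#N)NCCCCn1nc(-c2ccccc2)ccc1=O` reaches only a limit in this assay, > 100 mg/kg, and not a number. The step of an at least 1.2-fold lower number from compound 1 to compound 3 (0.11 log units; that floor lies within the scatter) therefore rests on that limit of > 100 mg/kg in this assay, at which 1 of the 3 values shown sits, and says no more than that the floor of the change lies within the scatter.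

Compound 4 `C/N=C(\NC#N)NCCCCn1nc(-c2ccccc2)ccc1=O` differs from compound 3 by a group of 6 heavy atoms (3 carbon, 3 nitrogen; no ring) in place of a group of 5 heavy atoms (2 carbon, 3 nitrogen; no ring), on an amine nitrogen. Going by the values given here, the one measured step at this position, an at least 1.2-fold lower number from compound 1 to compound 3 (0.11 log units; that floor lies within the scatter), is small and bounded by a limit; nothing among the measured compounds points to a change beyond the scatter when a small group is placed on this nitrogen. Compound 4 is thus expected to show a 1.2-fold higher number from compound 3 to compound 4 (0.07 log units; within the scatter) in this assay. For compound 4 the estimated value is 90 mg/kg, with an expected range from 45 mg/kg to 180 mg/kg.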

Compound 4, dose for half-maximal effect: 32.4 mg/kg
Compound 4: middle estimate off by 2.8-fold (0.44 log units), on the high side, outside the stated range (below it).
By their numbers in this assay, from the lowest: compound 4; then compounds 3 and 2 (each within the scatter of the next).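

In this assay, going by these compounds alone, the nitrogen of the cyanoguanidine proves sensitive to substitution: the group of 6 heavy atoms in place of the group of 5 heavy atoms, on an amine nitrogen, gives the first step at this position that lies beyond the scatter (a 2.4-fold lower number from compound 3 to compound 4 (0.38 log units; beyond the scatter)). The group of 8 heavy atoms does not share this gain, and replacing it with the group of 6 heavy atoms also gives a step beyond the scatter (an at least 3.0-fold lower number from compound 1 to compound 4 (0.48 log units; beyond the scatter)), so among these three compounds the lowest number belongs to the compound with the middle-sized group rather than to either end of the series. Compound 1 remains at a limit and not a number, so this second step gives only a floor: the limit of > 100 mg/kg in this assay, at which 1 of the 4 values shown sits.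

As far as these compounds go, compound 2 differs from compound 4 in more than one place, so the effect of an ethyl group on this nitrogen with the chain of compound 4 remains open. Also open, from the compounds shown here alone, is how a branched group such as isopropyl, or a ring such as cyclopropyl, would read on the same nitrogen.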